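A few compounds are considered here, and "the series" means these few. Any claim that something is new, unique, unknown or untested is made for them only; others in the source may bear on it.

Measured so far in a functional assay on A549 cells (Homo sapiens) for antiproliferative activity, read by MTT assay, with a stated time of 48 h (on this read-out lower numbers stand for stronger inhibition and higher numbers for weaker inhibition), are these compounds
- compound 1 `Clc1cc2nc(-c3cn(-c4ccccc4)nc3-c3ccccc3)[nH]c2cc1Cl` gives 11100 nM
- compound 2 `Clc1ccc(-c2nn(-c3ccccc3)cc2-c2nc3cc(Cl)c(Cl)cc3[nH]2)cc1` gives 19100 nM

Within the data shown here, compound 2 stands within the scatter of compound 1, the only other compound with a number. The next step leads to compound 3 `COc1ccc(-c2nn(-c3ccccc3)cc2-c2nc3cc(Cl)c(Cl)cc3[nH]2)cc1` with methoxy in place of chloro on an aromatic carbon in short, methoxy in place of chloro on an aromatic carbon, para to a large group. Among the measured compounds shown here, one measured step touches this carbon, a 1.7-fold higher number from compound 1 to compound 2 (0.24 log units; within the scatter) for chloro in place of hydrogen. For the measured compounds named here, with only this step to go on, no step beyond the scatter is expected in this assay for the new change. The estimated move is a 1.3-fold lower number from compound 2 to compound 3 (0.10 log units; within the scatter) and nothing larger is expected. For compound 3 the expected value is 15000 nM within an estimated range from 6000 nM to 35000 nM.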

Compound 3, half-maximal inhibitory concentration: 7330 nM
For compound 3 the middle estimate is 2.0-fold (0.31 log units) above the measured one; measured number inside the range.
By their numbers in this assay, from the lowest: compounds 3, 1 and 2 (each within the scatter of the next, the first and the last beyond it).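

Among these compounds, on this aromatic carbon, para to a large group, going from 4-chlorophenyl to 4-methoxyphenyl gives the first step beyond the scatter in this assay (a 2.6-fold lower number from compound 2 to compound 3 (0.42 log units; beyond the scatter)), so these two substituents can be told apart here. Neither separates from hydrogen, as methoxy stays within the scatter (a 1.5-fold lower number from compound 1 to compound 3 (0.18 log units; within the scatter)) and chloro does too (a 1.7-fold higher number from compound 1 to compound 2 (0.24 log units; within the scatter)). Nothing measured here accounts for the difference between chloro and methoxy.

Open, as far as these compounds go, is whether an amine, a carboxylic acid or a longer alkoxy chain on this carbon would move beyond hydrogen. The change is also seen on one core only.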